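This account rests on a few compounds, and the source may have more. Where it says the series, first, only, none or still open, it means among the compounds named here.

For the measured compounds named here, compound 3 `NS(=O)(=O)c1ccc(NC(=S)Nc2ccc3ncnc(Nc4cccc(C(F)(F)F)c4)c3c2)cc1` stands second highest of the three numbers so far in a functional assay on A-431 cells (Homo sapiens) for antiproliferative activity, read by MTT assay, with a stated time of 72 h (a higher number here means a weaker inhibitor, a lower number a stronger inhibitor), where compound 3 gives 21700 nM. Its nearest neighbour is compound 1 `COc1cc2ncnc(Nc3cccc(F)c3)c2cc1OCCCCC(=O)Nc1ccc(S(N)(=O)=O)cc1`, which in this assay gives 29900 nM, a gap within the scatter. Its furthest is compound 2 `COc1cc2ncnc(Nc3ccc(Br)cc3)c2cc1OCCCCC(=O)Nc1ccc(S(N)(=O)=O)cc1`, which in this assay gives 6570 nM, a gap beyond the scatter. Compound 4 `Cc1ccc(Nc2ncnc3ccc(NC(=S)Nc4ccc(S(N)(=O)=O)cc4)cc23)cc1` has not yet been measured. It differs from compound 3 in one place: 4-methylphenyl in place of 3-(trifluoromethyl)phenyl on a nitrogen on an aromatic ring. Going by the values given here, the one measured step, a 4.6-fold lower number from compound 1 to compound 2 (0.66 log units; beyond the scatter), likewise swaps one aryl group for another on the same kind of nitrogen and lowered the number beyond the scatter, but both the groups exchanged and the rest of the molecule differ from those here, so it bears on the present change only loosely. On that basis a modest lowering is expected, a 1.8-fold lower number from compound 3 to compound 4 (0.26 log units; within the scatter), with real doubt whether it clears the scatter. Compound 4 is therefore estimated at 12000 nM, within a range from 4000 nM to 40000 nM.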

Compound 4, half-maximal inhibitory concentration: 40000 nM
For compound 4 the middle estimate is 3.3-fold (0.52 log units) below the measured one, and the stated range covers the measured number.
By their numbers in this assay, from the lowest: compound 2; then compounds 3, 1 and 4 (each within the scatter of the next).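

In this assay the exchange of 3-(trifluoromethyl)phenyl for 4-methylphenyl on a nitrogen on an aromatic ring gives a 1.8-fold higher number from compound 3 to compound 4 (0.27 log units; within the scatter), so on the core of compound 3 these two aryl groups cannot be told apart. The earlier aryl exchange, a 4.6-fold lower number from compound 1 to compound 2 (0.66 log units; beyond the scatter), lies beyond the scatter but sits on a different molecule and involves different groups, so an aryl exchange on this kind of nitrogen does not always move the number beyond the scatter. No available evidence accounts for the outcome of this exchange.

From the compounds shown here alone, it remains open whether a phenyl ring carrying an amine or a carboxylic acid on this nitrogen would separate from these two groups. Going by these compounds, it is also open whether 4-bromophenyl would give a different number on the core of compound 3.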